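Sulfonyl substituent change on a shared pyrimidinone-type core series

The compounds below may be only part of what the source reports. "The series", "measured", "known", "first", "only" and "open" are said of these compounds alone.

Measured so far:
compound 1 `Cn1c(=O)c(S(=O)(=O)Cc2ccc(F)cc2)cc2cnc(Nc3ccc4[nH]ccc4c3)nc21`: 30000 nM
compound 2 `O=c1[nH]c2nc(Nc3ccc4[nH]ccc4c3)ncc2cc1S(=O)(=O)c1ccc(F)cc1F`: 15000 nM

In a functional assay on DU-145 cells (Homo sapiens) for inhibition, read by trypan blue exclusion, with a stated time of 72 h (on this read-out higher numbers stand for weaker inhibition and lower numbers for stronger inhibition), compound 1 gives 30000 nM, the highest of the two numbers. Compound 2 gives 15000 nM, within the scatter of compound 1, so the two show no ordered difference.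

Compound 3 `Cn1c(=O)c(S(=O)(=O)c2ccc(N)cc2F)cc2cnc(Nc3ccc4[nH]ccc4c3)nc21` is not yet measured. It differs from compound 1 in one place: 4-amino-2-fluorophenyl in place of 4-fluorobenzyl on a sulfonyl sulfur. Among the compounds with values here, no measured pair maps this change, and the one other measured compound sits within the scatter of compound 1, so no step beyond the scatter is expected in this assay, in either direction. Compound 3 is estimated at 20000 nM (range 5000 nM to 60000 nM), an expected step of a 1.5-fold lower number from compound 1 to compound 3 (0.18 log units; within the scatter).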

Compound 3, half-maximal inhibitory concentration: 8000 nM
For compound 3 the middle estimate is 2.5-fold (0.40 log units) above the measured one; measured number inside the range.
By their numbers in this assay, from the lowest: compounds 3, 2 and 1 (each within the scatter of the next, the first and the last beyond it).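

In this assay, within the data shown here, the sulfonyl substituent gives the first step beyond the scatter: 4-amino-2-fluorophenyl in place of 4-fluorobenzyl on a sulfonyl sulfur brings a modest gain in inhibition (a 3.8-fold lower number from compound 1 to compound 3 (0.57 log units; beyond the scatter)). This position on the shared core therefore responds to a change of substituent. No measurement shown bears on the cause of this step. As far as these compounds go, the benzyl-to-phenyl change and the amino group arrive together, so their separate shares remain open. From the compounds shown here alone, whether 4-aminophenyl or 4-hydroxyphenyl on the sulfonyl sulfur would keep the step is also open.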